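This account rests on a few compounds, and the source may have more. Where it says the series, first, only, none or still open, it means among the compounds named here.

Compound 1 `Nc1nc(N)nc(-c2cc(F)ccc2Cl)n1`: in a physicochemical assay for lipophilicity (a lower number here means a more polar compound, a higher number a more lipophilic compound), compound 1 gives 1.38.
Compound 2 `Nc1nc(N)nc(-c2cc(Br)ccc2Cl)n1`: in this assay compound 2 gives 2.04.
Compound 3 `Nc1nc(N)nc(-c2cc(Cl)ccc2Br)n1`: in this assay compound 3 gives 1.85.

Compound 2 and compound 3 are built from the same atoms joined differently; the difference between the two cores is not broken down here. Their values in this assay lie within the usual scatter of each other, so nothing is read into that pair. Compound 1 stands apart: its value in this assay is lower than that of compound 3, and that gap is beyond the scatter.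

Among the compounds with values here, the one counted step among the measured compounds is fluoro in place of bromo on an aromatic carbon, which gives a number 0.66 log units lower from compound 2 to compound 1 (beyond the scatter).

Compound 4 `Nc1nc(N)nc(-c2cc(Cl)ccc2F)n1` has not yet been measured. It differs from compound 3 by fluoro in place of bromo on an aromatic carbon. Within the data shown here, this is the same kind of change as the one from compound 2 to compound 1, not the same change: in compound 4 the new fluoro sits ortho to a group of 8 heavy atoms, whereas in compound 1 it sits meta to a group of 8 heavy atoms; in both it is para to a chloro group. With only one worked example of this change in hand, the expectation for compound 4 rests on that example alone. The step of a number 0.66 log units lower from compound 3 to compound 4 (beyond the scatter) is expected to be of about the size of a number 0.66 log units lower from compound 2 to compound 1 (beyond the scatter). On that basis compound 4 is estimated at 1.19 in this assay, expected to fall between 0.8 and 1.6.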

Compound 4, partition coefficient: 1.81
For compound 4 the middle estimate is 0.62 log units below the measured one; the whole stated range lies below it.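

In this assay, fluoro in place of bromo on an aromatic carbon gives two different readings in this series: (a number 0.66 log units lower from compound 2 to compound 1 (beyond the scatter)) and, with the new fluoro ortho to a group of 8 heavy atoms and para to a chloro group (a number 0.04 log units lower from compound 3 to compound 4 (within the scatter)). The first step is printed as beyond the scatter and the second as within it, so the size of this change does not carry from the core of compound 2 to the core of compound 3, and one worked example was not a sound guide to the other. This does not show what sets the two steps apart, and with only two pairs it gives no general rule for the change on other cores; no measurement shown here bears on the reason.

The compounds shown carry only fluoro, chloro and bromo on the aromatic ring, so they leave open how an amine, a carboxylic acid, a nitrile or a longer chain would read at either place. They also leave open whether a third core would follow the pair from compound 2 or the pair from compound 3, and a further pair with the same change would be needed to settle that.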